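The compounds below may be only part of what the source reports. "The series", "measured", "known", "first", "only" and "open" are said of these compounds alone.

Measured so far:
compound 1 `N=c1oc2ccc(Br)cc2cc1C(=O)NCCO`: 0%
compound 2 `COc1cc(Br)cc2cc(C(=O)NCCCO)c(=N)oc12`: 23%

In an assay on HeLa cells for displacement of a labelled ligand from adenosine receptor A3 (Homo sapiens), read by scintillation counting, with a stated time of 180 min, tested at 10 uM (a higher number here means more inhibition at the concentration tested (going by the name of the read-out), a lower number less inhibition), compound 1 gives 0%, the lower of the two numbers. Compound 2 gives 23%, which lies beyond the scatter above compound 1; the two differ in more than one place, so only their values can be set side by side. Compound 3 `N=c1oc2ccc(Br)cc2cc1C(=O)NC1CCCC1` has not been measured. It differs from compound 1 by cyclopentyl in place of 2-hydroxyethyl on an amide-type nitrogen. Going by the values given here, no single-change step between measured compounds is available to size this change, so any expectation rests on loose grounds. Compound 3 is expected to rise somewhat, the step of a number 20 percentage points higher from compound 1 to compound 3 (beyond the scatter) being an estimate. Compound 3 is estimated at 20%, between 0% and 55%.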

Compound 3, a percentage reported as inhibition, at one concentration (the size of the read-out at that concentration, not a potency): 0%
For compound 3 the middle estimate is 20 percentage points above the measured one; the range from low to high includes it.
By their numbers in this assay, from the lowest: compounds 1 and 3 (each within the scatter of the next); then compound 2.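

In this assay, cyclopentyl in place of 2-hydroxyethyl on the amide-type nitrogen gives no change at the digits printed from compound 1 to compound 3 (within the scatter), the first single-change step read at this position. Exchanging the open chain with its hydrogen-bond donor and acceptor for a carbon-only ring therefore leaves the number unmoved at the concentration tested. No evidence on the reason for this is available.

As far as these compounds go, whether a phenyl ring or a 2-aminoethyl chain on this nitrogen would move the number remains open. Also open, from the compounds shown here alone, is which difference gives compound 2 its 23%, since it differs from compound 1 in more than one place.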